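The source may hold more compounds than are shown below. What is called first, only, known or untested is meant among the compounds shown, and "the series" means these compounds.

Of the compounds shown here, three sharing one core have so far been tested in an ADME assay on HEK-293T cells (Homo sapiens) for cytotoxicity, read by luminescence, with a stated time of 24 h; on this read-out higher numbers stand for lower toxicity in this test and lower numbers for higher toxicity in this test. Compound 1 (`CCCNC(=O)c1cc2sccc2n1Cc1ccc(OC)cc1`) gives > 100000 nM, which is a limit of the assay and not a number. Compound 2 (`COc1ccc(Cn2c(C(=O)N3CCNCC3)cc3sccc32)cc1`) gives > 100000 nM, again a limit. Compound 3 (`COc1ccc(Cn2c(C(=O)N3CCC(C(=O)NC(C)c4ccccc4)CC3)cc3sccc32)cc1`) gives > 100000 nM, also a limit. Going by the values given here, it therefore stands level with the other two, and the whole series so far reads (the limit of > 100000 nM in this assay, at which 3 of the 3 values shown sit).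

The next structure is compound 4 (`COc1ccc(Cn2c(C(=O)N3CCC(C(=O)NCCC(C)C)CC3)cc3sccc32)cc1`), with isopentyl in place of 1-phenylethyl on an amide-type nitrogen.

Among the compounds with values here, the one measured step is a step that the two limits leave unreadable from compound 1 to compound 2. It is a different change and has no readable size, so it offers no size to carry over. The expectation therefore rests on compound 3 and its > 100000 nM, which is a limit. No step beyond the scatter is expected in this assay, in either direction. The expected step is a number no higher from compound 3 to compound 4 (the limit leaves the size open). The estimated value for compound 4 is 100000 nM, with an expected range from 40000 nM to 200000 nM.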

Compound 4, half-maximal cytotoxic concentration: 30900 nM
Compound 4: middle estimate off by 3.2-fold (0.51 log units), on the high side, and the stated range ends above it.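

In this assay, isopentyl in place of 1-phenylethyl on the amide-type nitrogen gives an at least 3.2-fold lower number from compound 3 to compound 4 (0.51 log units; beyond the scatter), so what sits at this position can move the read-out towards higher toxicity in this test. The three earlier compounds could not show this. Going by these compounds alone, compound 4 is the first with a number rather than a limit, which also means that the step from the phenyl-bearing group has no known upper size. On these data alone, that size stays open because the starting point is only a limit: the limit of > 100000 nM in this assay, at which 3 of the 4 values shown sit.

The compounds shown do not separate the loss of the six-membered aromatic ring from the arrival of the open isopentyl chain. A 1-cyclohexylethyl group or a straight pentyl chain on the same nitrogen would help to tell these two parts of the change apart.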